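Methoxy in place of hydrogen on compound 1

The source may hold more compounds than are shown below. What is called first, only, known or untested is meant among the compounds shown, and "the series" means these compounds.

Among the measured compounds shown here, compound 1 `O=C1NCCN1c1ccc(S(=O)(=O)Nc2ccccc2)cc1` gives 470 nM in a functional assay on MCF7 cells (Homo sapiens) for antiproliferative activity, read by sulforhodamine B assay, with a stated time of 48 h (a higher number here means a weaker inhibitor, a lower number a stronger inhibitor), the only plain number recorded here. Compound 2 `CCCCCCOc1ccc(NS(=O)(=O)c2ccc(N3CCNC3=O)cc2)cc1` in this assay gives > 1000 nM, which is a limit of the assay rather than a number (the limit of > 1000 nM in this assay, at which 1 of the 2 values shown sits). The step of an at least 2.1-fold higher number from compound 1 to compound 2 (0.32 log units; beyond the scatter) is the only measured one, and it bears on the change to compound 3 `COc1ccccc1NS(=O)(=O)c1ccc(N2CCNC2=O)cc1` only loosely, since it adds hexyloxy rather than methoxy. The change here is methoxy in place of hydrogen on an aromatic carbon. A modest weakening is therefore expected for compound 3, a 1.5-fold higher number from compound 1 to compound 3 (0.17 log units; within the scatter). Compound 3 is thus estimated at 700 nM, within a range of 300 nM to 1600 nM.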

Compound 3, half-maximal inhibitory concentration: 770 nM
The estimate for compound 3 lay 1.1-fold (0.04 log units) below the measured number; measured number inside the range.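

In this assay, methoxy on an aromatic carbon, ortho to a large group, gives a 1.6-fold higher number from compound 1 to compound 3 (0.21 log units; within the scatter), so compound 1 and compound 3 cannot be told apart and this change at this position costs no measurable activity. Among the compounds shown here, this is the first plain number for a group added to this ring, which the hexyloxy of compound 2 could not supply. Compound 2 remains a limit and not a number: the limit of > 1000 nM in this assay, at which 1 of the 3 values shown sits.

Open still is how methoxy would read on the other carbons of this ring. Also open, from the compounds shown here alone, is what fluorine, an amine, a carboxylic acid or a chain of intermediate length would do here.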